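Pyridine for phenyl on the aryl nitrogen of compound 1

A few compounds are considered here, and "the series" means these few. Any claim that something is new, unique, unknown or untested is made for them only; others in the source may bear on it.

Measured compounds:
compound 1 `CC(C)OC(=O)N1CCC(Oc2ncnc3c2CCN3c2ccc(S(C)(=O)=O)cc2)CC1`: 126 nM
compound 2 `CCS(=O)(=O)N1CCC(Oc2ncnc3c2CCN3c2ccc(S(C)(=O)=O)cc2F)CC1`: 1580 nM
compound 3 `CN(C)S(=O)(=O)N1CCC(Oc2ncnc3c2CCN3c2ccc(S(C)(=O)=O)cc2F)CC1`: 398 nM

In a functional assay on CHO-K1 cells for agonist activity at Glucose-dependent insulinotropic receptor (Homo sapiens), read by a luciferase reporter, with a stated time of 5 h (a lower number here means that less compound is needed, a higher number that more compound is needed for the effect), compound 1 gives 126 nM, the lowest of the three numbers; compound 3 stands nearest to it and compound 2 furthest. Within the data shown here, the only step between measured compounds that differ in one place is a 4.0-fold lower number from compound 2 to compound 3 (0.60 log units; beyond the scatter), a change on the sulfonyl sulfur of the piperidine substituent, which is a different part of the molecule from the one altered here.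

Compound 4 `CC(C)OC(=O)N1CCC(Oc2ncnc3c2CCN3c2ccc(S(C)(=O)=O)cn2)CC1` differs from compound 1 in one place: 5-(methylsulfonyl)pyridin-2-yl in place of 4-(methylsulfonyl)phenyl on a nitrogen on an aromatic ring in a ring. Among the measured compounds shown here, no measured pair shows this exchange, so nothing in the data speaks directly to its size or direction. With the rest of compound 1 kept intact, the number in this assay is expected to stay near that of compound 1, within or close to the scatter, and the estimated step is a 1.2-fold higher number from compound 1 to compound 4 (0.08 log units; within the scatter). Compound 4 is therefore estimated at 150 nM, with a range from 50 nM to 450 nM.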

Compound 4, half-maximal effective concentration: 126 nM
The estimate for compound 4 lay 1.2-fold (0.08 log units) above the measured number, and the stated range covers the measured number.
By their numbers in this assay, from the lowest: compounds 1 and 4 (each within the scatter of the next); then compound 3; then compound 2.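

In this assay, among these compounds, the exchange of 4-(methylsulfonyl)phenyl for 5-(methylsulfonyl)pyridin-2-yl gives no change at the digits printed from compound 1 to compound 4 (within the scatter) and so provides the first measured change at this position, as the earlier step concerned only a sulfonyl sulfur elsewhere in the molecule. Here, a six-membered aromatic ring with one hetero atom and one more hydrogen-bond acceptor by count takes the place of the all-carbon ring without moving the number beyond the scatter. No measurement shown here accounts for this outcome.

On these data alone, it remains open whether the same exchange would hold in compound 2 or compound 3, whose other substituents differ from those of compound 1. Also unknown is how this position would respond to a pyrimidine ring, or to a nitrile or a carboxylic acid in place of the methylsulfonyl group.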